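This account rests on a few compounds, and the source may have more. Where it says the series, first, only, none or still open, it means among the compounds named here.

Measured compounds in a functional assay on HEK293 cells for positive allosteric modulation of metabotropic glutamate receptor 5 (Homo sapiens), read by calcium flux; on this read-out lower numbers stand for smaller maximal responses and higher numbers for larger maximal responses:

Compound 1 `O=C1c2cc(COc3ccccc3)nn2CCN1c1ccccc1F` gives 86%.
Compound 2 `O=C1c2cc(COc3ccccc3)nn2CCN1c1ccc(F)cc1` gives 79%.
Compound 3 `O=C1c2cc(COc3ccccc3)nn2CCN1c1ccc(F)c(F)c1` gives 81%.

All three share one core and differ only in the fluorine pattern of the aryl group on the amide-type nitrogen in the ring. Compound 2 sits at the low end of the three numbers, but the steps around it are small: a number 7 percentage points lower from compound 1 to compound 2 (within the scatter), and a number 2 percentage points higher from compound 2 to compound 3 (within the scatter). Neither marks a real difference in this assay.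

Compound 4 `O=C1c2cc(COc3ccccn3)nn2CCN1c1ccc(F)cc1` keeps the 4-fluorophenyl of compound 2 and alters the other end of the molecule: pyridin-2-yl in place of phenyl on an oxygen on a saturated carbon

Among the compounds with values here, none of the measured steps touches that position; the steps of a number 7 percentage points lower from compound 1 to compound 2 (within the scatter), a number 5 percentage points lower from compound 1 to compound 3 (within the scatter) and a number 2 percentage points higher from compound 2 to compound 3 (within the scatter) all concern the aryl on the nitrogen, and all fall within the scatter. For the phenoxy to (pyridin-2-yl)oxy change there is no comparison at all among the three measured compounds, so nothing argues for a shift in either direction beyond the scatter.

Compound 4 is therefore expected to give about 78%, with a range from 62% to 94%. This estimate corresponds to an expected step of a number 1 percentage points lower from compound 2 to compound 4 (within the scatter).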

Compound 4, largest response reached (Emax), in percent of the reference or control that the assay uses: 68%
For compound 4 the middle estimate is 10 percentage points above the measured one; measured number inside the range.
By their numbers in this assay, from the lowest: compound 4; then compounds 2, 3 and 1 (each within the scatter of the next).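

The phenoxy end of the molecule, which the earlier compounds left unchanged, proves able to move the response in this assay: with the 4-fluorophenyl held constant, pyridin-2-yl in place of phenyl on an oxygen on a saturated carbon gives a number 11 percentage points lower from compound 2 to compound 4 (beyond the scatter) and this modest step is the only one shown that lies beyond the scatter. The swap leaves the count of heavy atoms unchanged, exchanging one ring carbon for nitrogen and adding one hydrogen-bond acceptor. Nothing available here explains why the response differs between these two compounds.

Still open, from the compounds shown here alone, is whether pyridin-3-yl or pyridin-4-yl on the same oxygen would behave like pyridin-2-yl, or whether a saturated cyclohexyl group would be tolerated there. Going by these compounds, it is equally open whether the step carries over to the 2-fluorophenyl of compound 1 or the 3,4-difluorophenyl of compound 3.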